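Butyl ester to glycol chain: estimate for compound 4

The source may hold more compounds than are shown below. What is called first, only, known or untested is meant among the compounds shown, and "the series" means these compounds.

In an ADME assay on RAW264.7 cells (Mus musculus) for cytotoxicity, read by MTT assay, with a stated time of 24 h (on this read-out higher numbers stand for lower toxicity in this test and lower numbers for higher toxicity in this test), compound 1 (`CC/C=C\C[C@H]1C(=O)C=C[C@H]1CC(=O)OCCCC`) gives 31 uM, compound 2 (`CC/C=C\C[C@H]1C(=O)C=C[C@H]1CC(=O)Oc1ccc(O)cc1`) gives 49 uM and compound 3 (`CC/C=C\C[C@H]1C(=O)C=C[C@H]1CC(=O)Oc1ccccc1OC`) gives 161 uM. Compound 1 therefore lies within the scatter of compound 2, while compound 3 gives a higher number than both. Compound 4 (`CC/C=C\C[C@H]1C(=O)C=C[C@H]1CC(=O)OCCOCCOCCO`) has 2-(2-hydroxyethoxy)ethoxy in place of ethyl on a saturated chain carbon, two bonds along the chain from an oxygen next to a carbonyl group. For the measured compounds named here, the one measured step bearing on this change is a 1.6-fold higher number from compound 1 to compound 2 (0.20 log units; within the scatter), which also alters the group on that oxygen. On that basis, no step beyond the scatter is expected in this assay, and the estimated step is a 1.5-fold higher number from compound 1 to compound 4 (0.19 log units; within the scatter). For compound 4 the estimated value is 48 uM, with an expected range of 20 uM to 130 uM.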

Compound 4, half-maximal toxic concentration: 162 uM
Compound 4: the middle estimate sits 3.4-fold (0.53 log units) below what was measured; measured number outside the range, above it.
By their numbers in this assay, from the lowest: compounds 1 and 2 (each within the scatter of the next); then compounds 3 and 4 (each within the scatter of the next).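

At this place, on a saturated chain carbon, two bonds along the chain from an oxygen next to a carbonyl group, the change to 2-(2-hydroxyethoxy)ethoxy moves the number in this assay beyond the scatter (a 5.2-fold higher number from compound 1 to compound 4 (0.72 log units; beyond the scatter)), whereas the change to 4-hydroxyphenyl stays within it (a 1.6-fold higher number from compound 1 to compound 2 (0.20 log units; within the scatter)). Higher numbers stand for lower toxicity in this test, so this longer chain is accepted here with lower, not higher, toxicity.

Open, going by these compounds, is whether a shorter 2-hydroxyethyl group, or an amine in place of the hydroxyl, would give the same step. Nothing at hand explains the step.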